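The source may report more compounds than this note shows. Statements on the series, on what has been measured and on what is new or still open speak of the compounds shown alone.

Of the compounds shown here, three sharing one core have been tested in a functional assay, read by spectrophotometry, with a stated time of 2 h, tested at 3 mg/mL; a higher number here means a stronger effect of the compound at the concentration tested, a lower number a weaker effect. Compound 1 `CC(C)[C@@H]1CC[C@@H](C)C[C@@]12N(C)C(=O)[C@@H]1[C@H]3C(=O)N(c4ccccc4)C(=O)[C@H]3ON12` gives 58.9%, compound 2 `CC(C)[C@@H]1CC[C@@H](C)C[C@@]12N(C)C(=O)[C@@H]1[C@H]3C(=O)N(c4ccc(Cl)cc4)C(=O)[C@H]3ON12` gives 73.3%, and compound 3 `COc1ccc(N2C(=O)[C@H]3[C@H](ON4[C@@H]3C(=O)N(C)[C@@]43C[C@H](C)CC[C@H]3C(C)C)C2=O)cc1` gives 67.7%. Within the data shown here, compound 3 sits close to both neighbours: the step of a number 5.6 percentage points lower from compound 2 to compound 3 (within the scatter) and the step of a number 8.8 percentage points higher from compound 1 to compound 3 (within the scatter) are each within the scatter, while only the step of a number 14.4 percentage points higher from compound 1 to compound 2 (beyond the scatter) reaches beyond it. Compound 4 `Cc1ccc(N2C(=O)[C@H]3[C@H](ON4[C@@H]3C(=O)N(C)[C@@]43C[C@H](C)CC[C@H]3C(C)C)C2=O)c(C)c1` differs from compound 3 by 2,4-dimethylphenyl in place of 4-methoxyphenyl on an amide-type nitrogen in a ring. Among the measured compounds shown here, no measured step swaps one ring substituent pattern for methyl groups, so the nearest guidance is that the aryl substituent changes seen so far moved this assay little or modestly. Compound 4 is therefore expected to show a number 2.7 percentage points lower from compound 3 to compound 4 (within the scatter), an estimate of 65% within 50% to 80%.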

Compound 4, a percentage reported as activity, at one concentration (the size of the read-out at that concentration, not a potency): 71.3%
Estimate against measurement, compound 4: 6.3 percentage points below; the measured number falls inside the stated range.
By their numbers in this assay, from the lowest: compounds 1, 3, 4 and 2 (each within the scatter of the next, the first and the last beyond it).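

In this assay, the steps of a number 3.6 percentage points higher from compound 3 to compound 4 (within the scatter) and a number 2 percentage points lower from compound 2 to compound 4 (within the scatter) show that 2,4-dimethylphenyl, which has no hydrogen-bond acceptor, cannot be told apart from 4-methoxyphenyl or 4-chlorophenyl on this amide-type nitrogen. The step of a number 12.4 percentage points higher from compound 1 to compound 4 (beyond the scatter) places it with 4-chlorophenyl as the second replacement to clear the scatter against plain phenyl. Nothing measured explains these steps. Going by these compounds, what remains open is how an amine, a carboxylic acid or a longer chain on the aromatic ring would fare. The compounds also leave open what each methyl group contributes alone.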